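The source may hold more compounds than are shown below. What is called first, only, known or untested is meant among the compounds shown, and "the series" means these compounds.

Measured so far in a functional assay on MX1 cells (Homo sapiens) for inhibition, read by MTT assay, with a stated time of 120 h; a lower number here means a stronger inhibitor, a higher number a weaker inhibitor:
- Compound 1 `CNC(=O)/C(C)=C/c1ccc(NC(=O)Nc2ccc(Cl)c(C(F)(F)F)c2)cc1`: > 50000 nM
- Compound 2 `CC(NC(=O)CCc1ccc(NC(=O)Nc2ccc(Cl)c(C(F)(F)F)c2)cc1)c1ccccc1`: > 50000 nM
- Compound 3 `CNC(=O)c1cccc(-c2ccc(NC(=O)Nc3ccc(Cl)c(C(F)(F)F)c3)cc2)c1`: > 50000 nM

Each of these entries is a limit of the assay and not a number. Compound 3 therefore has no exact position on the scale, and its entry of > 50000 nM is only a limit. Among the compounds with values here, the whole series so far comes down to the limit of > 50000 nM in this assay, at which 3 of the 3 values shown sit.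

Compound 4 `CNC(=O)CCc1ccc(NC(=O)Nc2ccc(Cl)c(C(F)(F)F)c2)cc1` comes next. It carries 2-(methylcarbamoyl)ethyl in place of 3-(methylcarbamoyl)phenyl on an aromatic carbon, para to a large group: 2-(methylcarbamoyl)ethyl in place of 3-(methylcarbamoyl)phenyl on an aromatic carbon.

Within the data shown here, one measured step bears on this change, as it alters the same place: a step that the two limits leave unreadable from compound 1 to compound 3. It offers no size to carry over. Since all three compounds sit on the limit in this assay, no step beyond the scatter and no particular direction can be expected, and a further limit is the likeliest result.

The expected step is a number no higher from compound 3 to compound 4 (the limit leaves the size open). For compound 4, the estimate is 50000 nM, with an expected range of 25000 nM to 100000 nM.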

Compound 4, half-maximal inhibitory concentration: 20400 nM
The estimate for compound 4 lay 2.5-fold (0.39 log units) above the measured number; measured number below the stated range.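

Compound 4 is the only one of the four compounds with an exact reading in this assay: the limit of > 50000 nM in this assay, at which 3 of the 4 values shown sit.

At the aromatic carbon para to a large group, 2-(methylcarbamoyl)ethyl brings an at least 2.4-fold lower number from compound 3 to compound 4 (0.38 log units; beyond the scatter) in place of 3-(methylcarbamoyl)phenyl, and an at least 2.4-fold lower number from compound 1 to compound 4 (0.38 log units; beyond the scatter) in place of 2-(methylcarbamoyl)prop-1-en-1-yl. The amide-type nitrogen matters too: methyl in place of 1-phenylethyl brings an at least 2.4-fold lower number from compound 2 to compound 4 (0.38 log units; beyond the scatter), and one end of each of these three steps is a limit, so only a smallest size is known.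

The compounds shown leave open whether the number would fall further with a longer chain carrying the same methyl amide, or with a carboxylic acid in place of that amide. They also leave open how an ethyl group in place of methyl on the amide-type nitrogen would read.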